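Trimming ethoxy to methoxy on compound 3

A few compounds are considered here, and "the series" means these few. Any claim that something is new, unique, unknown or untested is made for them only; others in the source may bear on it.

In an in vitro ADME assay on microsomes (Homo sapiens) for metabolic stability (a lower number here means that the compound disappears faster, a higher number that the compound lasts longer), compound 3 `CCOc1nc(-c2ccc(Cl)cc2Cl)c(CC)nc1NC(CC)CC` gives 2 h. That is level with compound 1 `CCc1nc(NC(CC)CC)c(OC)nc1-c1ccc(OC(F)F)cc1Cl` at 2 h. Compound 2 `CCc1nc(NC(CC)CC)c(Cl)nc1-c1ccc(Cl)cc1Cl` gives 0.167 h. Compound 1 and compound 3 both lie well beyond the scatter from that number.

The next structure is compound 4 `CCc1nc(NC(CC)CC)c(OC)nc1-c1ccc(Cl)cc1Cl`, and the change is hydrogen in place of methyl on a saturated chain carbon bound to an oxygen on an aromatic ring. This puts hydrogen in place of methyl on a saturated chain carbon bound to an oxygen on an aromatic ring, so ethoxy becomes methoxy.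

Among the compounds with values here, no measured step tests this swap directly. Within the data shown here, the only step available, a 12-fold higher number from compound 2 to compound 3 (1.08 log units; beyond the scatter), is large, but it comes from ethoxy in place of chloro on an aromatic carbon, a different exchange. The closer hint is that compound 1, which also carries methoxy but differs elsewhere, reaches 2 h.

The expected result in this assay is therefore no shift beyond the scatter, with no change at the digits printed from compound 3 to compound 4 (within the scatter) as the estimated step. For compound 4 the estimated half-life is 2 h, within a range of 0.8 h to 4 h.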

Compound 4, half-life: 0.583 h
Compound 4: middle estimate off by 3.4-fold (0.54 log units), on the high side, and the stated range ends above it.
By their numbers in this assay, from the lowest: compound 2; then compound 4; then compounds 1 and 3 (each within the scatter of the next).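

In this assay, this position proves sensitive to a single carbon: with hydrogen in place of methyl on a saturated chain carbon bound to an oxygen on an aromatic ring, the result is a 3.4-fold lower number from compound 3 to compound 4 (0.54 log units; beyond the scatter), so ethoxy and methoxy are not interchangeable here. Methoxy still beats chloro at that spot, with a 3.5-fold higher number from compound 2 to compound 4 (0.54 log units; beyond the scatter), but it recovers only part of the gain seen with ethoxy. Methoxy alone also does not settle the half-life, since the group elsewhere on the molecule counts too, as a 3.4-fold lower number from compound 1 to compound 4 (0.54 log units; beyond the scatter) shows.

Nothing shown gives a reason for these shifts.

Open questions remain as to whether a longer chain, such as propoxy, would raise the number further, and whether an amine at that carbon would hold it. Going by these compounds, it also remains unknown how ethoxy and difluoromethoxy would behave together in one compound.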